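Halogen Swap on the Phenyl Ring of Compound 2

The source may report more compounds than this note shows. Statements on the series, on what has been measured and on what is new or still open speak of the compounds shown alone.

Three measured compounds share one core. In a functional assay on A549 cells (Homo sapiens) for inhibition, read by CCK-8 assay (on this read-out higher numbers stand for weaker inhibition and lower numbers for stronger inhibition), compound 1 `Oc1ccccc1/C=N/c1nnc(SCc2nnc(-c3ccccc3)o2)s1` gives 4110 nM. Compound 2 `Oc1ccccc1/C=N/c1nnc(SCc2nnc(-c3ccccc3Cl)o2)s1` gives 18100 nM in this assay, and compound 3 `Oc1ccccc1/C=N/c1nnc(SCc2nnc(-c3ccc(Cl)cc3)o2)s1` gives 30100 nM. Among these three numbers compound 2 stands second highest: the step of a 4.4-fold higher number from compound 1 to compound 2 (0.64 log units; beyond the scatter) lies beyond the scatter, whereas the step of a 1.7-fold higher number from compound 2 to compound 3 (0.22 log units; within the scatter) stays within it. The step of a 7.3-fold higher number from compound 1 to compound 3 (0.86 log units; beyond the scatter) is likewise beyond the scatter.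

Compound 4 `Oc1ccccc1/C=N/c1nnc(SCc2nnc(-c3ccc(Br)cc3)o2)s1` differs from compound 2 in one place: 4-bromophenyl in place of 2-chlorophenyl on an aromatic carbon. Among the compounds with values here, two measured steps bear on this change. The step of a 1.7-fold higher number from compound 2 to compound 3 (0.22 log units; within the scatter) shows that moving the chlorine from the 2-chlorophenyl to the 4-chlorophenyl produced no change beyond the scatter, and compound 3 with its 4-chlorophenyl is the closest measured counterpart of the 4-bromophenyl in compound 4. Within the data shown here, no measured pair compares bromine with chlorine, so that part of the change carries no evidence of its own. The expected step of a 1.5-fold higher number from compound 2 to compound 4 (0.19 log units; within the scatter) is therefore small, within the scatter, with the number estimated to sit close to that of compound 3. Compound 4 is expected to give about 28000 nM in this assay, within a range of 9000 nM to 90000 nM.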

Compound 4, half-maximal inhibitory concentration: 20000 nM
Estimate against measurement, compound 4: 1.4-fold (0.15 log units) above; low and high end bracket the measured number.
By their numbers in this assay, from the lowest: compound 1; then compounds 2, 4 and 3 (each within the scatter of the next).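

Within the data shown here, the direct comparison of bromine with chlorine that the earlier compounds lacked now exists: in this assay, bromo in place of chloro on this phenyl ring gives a 1.5-fold lower number from compound 3 to compound 4 (0.18 log units; within the scatter) and stays within the scatter, so this assay does not separate the two halogens here. The full change from 2-chlorophenyl to 4-bromophenyl gives a 1.1-fold higher number from compound 2 to compound 4 (0.04 log units; within the scatter) and also stays within the scatter, whereas bromo in place of hydrogen gives a 4.9-fold higher number from compound 1 to compound 4 (0.69 log units; beyond the scatter) and lies beyond it. Compound 4 thus joins compound 2 and compound 3 as a third halogen-bearing compound with a higher number than compound 1, and nothing available explains why a halogen on this phenyl ring goes with that higher number.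

The compounds shown leave open whether a group other than chloro or bromo on this ring, such as a methoxy group, an amine or a carboxylic acid, would bring the number back toward that of compound 1 or take it lower still. They also leave open how a 2-bromophenyl would compare with compound 2, and whether these steps would hold on a changed core.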